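Swapping the Halogenated Phenyl Group of Compound 1

The source may report more compounds than this note shows. Statements on the series, on what has been measured and on what is new or still open speak of the compounds shown alone.

Going by the values given here, in a functional assay on PC-3 cells (Homo sapiens) for antiproliferative activity, read by MTT assay, with a stated time of 48 h (on this read-out higher numbers stand for weaker inhibition and lower numbers for stronger inhibition), compound 1 `O=C(/C=C/c1ccccc1)Nc1cc2c(Nc3ccc(F)c(Cl)c3)ncnc2s1` gives 700 nM and holds the highest of the three numbers so far, which makes it the weakest inhibitor. Compound 2 `O=C(/C=C/c1ccccc1)Nc1cc2ncnc(Nc3ccc(F)c(Cl)c3)c2s1` gives 200 nM and compound 3 `O=C(/C=C/c1ccccc1)Nc1cc2ncnc(Nc3cc(Cl)cc(Cl)c3)c2s1` gives 220 nM as the two lower numbers, both beyond the scatter from compound 1. Compound 4 `O=C(/C=C/c1ccccc1)Nc1cc2c(Nc3cc(Cl)cc(Cl)c3)ncnc2s1` differs from compound 1 in one place, with 3,5-dichlorophenyl in place of 3-chloro-4-fluorophenyl on a nitrogen on an aromatic ring as the change, namely 3,5-dichlorophenyl in place of 3-chloro-4-fluorophenyl on a nitrogen on an aromatic ring. Among the compounds with values here, the one measured step bearing on this is the same swap, which gave a 1.1-fold higher number from compound 2 to compound 3 (0.04 log units; within the scatter) and so no real change. No step beyond the scatter is expected in this assay here, so the expected change is a 1.1-fold higher number from compound 1 to compound 4 (0.03 log units; within the scatter) only. Compound 4 is therefore expected at 750 nM with a range from 350 nM to 1600 nM as the likely span.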

Compound 4, half-maximal inhibitory concentration: 390 nM
Compound 4: middle estimate off by 1.9-fold (0.28 log units), on the high side; measured number inside the range.
By their numbers in this assay, from the lowest: compounds 2, 3, 4 and 1 (each within the scatter of the next, the first and the last beyond it).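

The swap to 3,5-dichlorophenyl on a nitrogen on an aromatic ring now has a second reading, a 1.8-fold lower number from compound 1 to compound 4 (0.25 log units; within the scatter), so on neither core does it move the number beyond the scatter. The two cores also answer this swap alike, as far as the scatter can tell: the same change on two cores in this assay, a 1.1-fold higher number (0.04 log units; within the scatter) from compound 2 to compound 3 and a 1.8-fold lower number (0.25 log units; within the scatter) from compound 1 to compound 4, 2.0-fold (0.30 log units) apart, within the scatter of two such steps

Both groups compared here are halogenated phenyl rings, so the compounds shown leave open how a plain phenyl ring, or a cyclohexyl group with no aromatic ring at all, would read on this nitrogen.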